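The source may hold more compounds than are shown below. What is called first, only, known or untested is meant among the compounds shown, and "the series" means these compounds.

Series notes. Compound 1 `COc1ccc(-n2ncc3c(NC(C4CC4)C4CC4)nc(C)nc32)c(C)c1` gives 32 nM in a functional assay on CHO cells for antagonist activity at corticotropin-releasing factor receptor 1 (Homo sapiens), read by cAMP accumulation; a higher number here means a weaker inhibitor, a lower number a stronger inhibitor; compound 2 `COc1ccc(-n2cnc3c(NC(C4CC4)C4CC4)nc(C)nc32)c(C)c1` gives 47 nM; compound 3 `COCc1nc2c(NC(C3CC3)C3CC3)nc(C)nc2n1-c1ccc(OC)cc1` gives 157 nM, the highest number of the three, with compound 2 the nearest and compound 1 the furthest, both gaps lying beyond the scatter. Compound 4 `COc1ccc(-n2c(C3CCCO3)nc3c(NC(C4CC4)C4CC4)nc(C)nc32)cc1` is not yet measured. It differs from compound 3 by a single change, (oxolan-2-yl in place of methoxymethyl on an aromatic carbon). Going by the values given here, no measured pair in the set traces a comparable exchange, so there is no precedent to lean on; the expected step from compound 3 to compound 4 is a 1.4-fold lower number from compound 3 to compound 4 (0.15 log units; within the scatter), a modest move towards a lower number that may well stay within the scatter. Compound 4 is estimated at 110 nM, with a range of 40 nM to 350 nM.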

Compound 4, inhibition constant: 867 nM
For compound 4 the middle estimate is 7.9-fold (0.90 log units) below the measured one; the measured number lies above the stated range.
By their numbers in this assay, from the lowest: compounds 1 and 2 (each within the scatter of the next); then compound 3; then compound 4.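

In this assay the aromatic carbon between two ring nitrogen atoms responds clearly to its substituent: oxolan-2-yl in place of methoxymethyl brings a 5.5-fold higher number from compound 3 to compound 4 (0.74 log units; beyond the scatter) and marks this position as sensitive to the exchange. Both groups count one hydrogen-bond acceptor and no donor, so the step goes with the five-membered non-aromatic ring and its larger heavy-atom count, not with a change in those counts. Nothing at hand gives a cause for this step. Going by these compounds, whether the ring itself or the added size matters stays open, and an open-chain ethoxymethyl group at this carbon would separate the two. On these data alone, how an amine such as aminomethyl behaves here also remains open.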